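Trifluoromethyl for butyl on a cinnamide inhibitor

This account rests on a few compounds, and the source may have more. Where it says the series, first, only, none or still open, it means among the compounds named here.

Two compounds have numbers in a functional assay on CHO cells for inhibition of transient receptor potential cation channel subfamily V member 1 (Homo sapiens) (a higher number here means a weaker inhibitor, a lower number a stronger inhibitor), so far. Compound 1 `CC(C)(C)c1ccc(/C=C/C(=O)Nc2ccc3c(c2)NCCC3)cc1` gives 160 nM in this assay. Compound 2 `CCCCc1ccc(/C=C/C(=O)Nc2ccc3c(c2)OCCO3)cc1` gives 2700 nM in this assay, the higher of the two numbers; its gap to compound 1 lies beyond the scatter, and compound 2 therefore stands as the weaker inhibitor of the pair. For the measured compounds named here, the two compounds also differ in their core, so no single step between them can be read out.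

Compound 3 `O=C(/C=C/c1ccc(C(F)(F)F)cc1)Nc1ccc2c(c1)OCCO2` keeps the core of compound 2 and changes only one thing: trifluoromethyl in place of butyl on an aromatic carbon. Going by the values given here, no measured pair shows this exchange. Both groups are without ring, donor, acceptor or charge, so a step of moderate size in either direction, or none beyond the scatter, seems possible. On that basis compound 3 is expected to give about 3000 nM in this assay, within 800 nM to 12000 nM. The expected step of a 1.1-fold higher number from compound 2 to compound 3 (0.05 log units; within the scatter) is thus small.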

Compound 3, half-maximal inhibitory concentration: 100 nM
Compound 3: the middle estimate sits 30-fold (1.48 log units) above what was measured; the measured number lies below the stated range.
By their numbers in this assay, from the lowest: compounds 3 and 1 (each within the scatter of the next); then compound 2.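

With the core of compound 2 held fixed, the group on this aromatic carbon, para to a large group, proves decisive in this assay: trifluoromethyl in place of butyl gives a 27-fold lower number from compound 2 to compound 3 (1.43 log units; beyond the scatter). The two groups match in heavy-atom count and in having no ring, donor, acceptor or charge, so these counts do not separate them, yet the step is large. Nothing measured here explains the size of this step.

Going by these compounds, it remains open whether the step reflects the arrival of trifluoromethyl or simply the loss of butyl, a question that a chlorine atom, a methoxy group or a shorter chain such as ethyl at this place on the same core could help settle. On these data alone, it also remains open whether trifluoromethyl would bring a step of similar size on the core of compound 1.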